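Oxan-4-yl replacing 3-chlorophenyl: cytotoxicity outlook

The compounds below may be only part of what the source reports. "The series", "measured", "known", "first", "only" and "open" are said of these compounds alone.

Compound 1 `COc1nc(-c2cccc(Cl)c2)ccc1[C@@H](c1ccccc1)[C@@](O)(CCN(C)C)c1cccc2ccccc12` stands at a limit in a toxicity assay on Vero cells (Chlorocebus sabaeus) for cytotoxicity; a higher number here means that more compound is tolerated, a lower number that less compound is tolerated: compound 1 gives > 50 ug/mL, a limit of the assay and not a number. Compound 2 `COc1nc(-c2ccccc2Cl)ccc1[C@@H](c1ccccc1)[C@@](O)(CCN(C)C)c1cccc2ccccc12` likewise gives a limit, > 50 ug/mL, in this assay. The step that the two limits leave unreadable from compound 1 to compound 2 thus has no readable size; (the limit of > 50 ug/mL in this assay, at which 2 of the 2 values shown sit). Compound 3 `COc1nc(C2CCOCC2)ccc1[C@@H](c1ccccc1)[C@@](O)(CCN(C)C)c1cccc2ccccc12` differs from compound 1 by oxan-4-yl in place of 3-chlorophenyl on an aromatic carbon. Among the measured compounds shown here, no measured step bears on this change, and compound 1 offers only a limit as a starting point. The expected step that the limit leaves unreadable from compound 1 to compound 3 is none beyond the scatter. Compound 3 is estimated at 65 ug/mL, with a range from 35 ug/mL to 120 ug/mL.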

Compound 3, half-maximal cytotoxic concentration: > 50 ug/mL
Compound 3: only a limit was reported (the forecaster's own chance of this, stated with the estimate: 80%); the middle value does not contradict the limit.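

Among the compounds shown here, compound 1, compound 2 and compound 3 all give limits, not numbers, in this assay, so no step among them can be read: the limit of > 50 ug/mL in this assay, at which 3 of the 3 values shown sit. Going by these compounds, whether oxan-4-yl and the chlorophenyl groups differ at all in this assay remains open.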